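Aryl group exchange in a small antiproliferative series

The source may report more compounds than this note shows. Statements on the series, on what has been measured and on what is new or still open speak of the compounds shown alone.

Going by the values given here, in a functional assay on MDA-MB-436 cells (Homo sapiens) for antiproliferative activity, read by MTT assay, with a stated time of 48 h (on this read-out lower numbers stand for stronger inhibition and higher numbers for weaker inhibition), compound 1 `CCCNC(=O)N1CCN(c2ncnc3sc(-c4ccc(N5CCN(C)CC5)cc4)cc23)CC1` gives 12400 nM and compound 2 `CN1CCN(c2ccc(-c3cc4c(N5CCN(C(=O)Nc6ccc(Cl)c(C(F)(F)F)c6)CC5)ncnc4s3)cc2)CC1` gives 3500 nM, the lower of the two numbers so far. Among the compounds with values here, the only measured step, a 3.5-fold lower number from compound 1 to compound 2 (0.55 log units; beyond the scatter), is modest but beyond the scatter; it put 4-chloro-3-(trifluoromethyl)phenyl in place of propyl on an amide-type nitrogen. Compound 3 `CN1CCN(c2ccc(-c3cc4c(N5CCN(C(=O)Nc6cc(C(F)(F)F)ccc6F)CC5)ncnc4s3)cc2)CC1` differs from compound 2 at that same place: 2-fluoro-5-(trifluoromethyl)phenyl in place of 4-chloro-3-(trifluoromethyl)phenyl on an amide-type nitrogen. Here 2-fluoro-5-(trifluoromethyl)phenyl replaces 4-chloro-3-(trifluoromethyl)phenyl. Within the data shown here, no measured step exchanges one aryl group for another, so the data give no direction for this change. An exchange of this kind is expected to stay smaller than the propyl replacement, a 3.5-fold lower number from compound 1 to compound 2 (0.55 log units; beyond the scatter). In this assay the expected step is a 1.1-fold lower number from compound 2 to compound 3 (0.04 log units; within the scatter), with nothing beyond the scatter anticipated. For compound 3 the estimate is 3200 nM, with an expected range of 1300 nM to 8000 nM.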

Compound 3, half-maximal inhibitory concentration: 8840 nM
Estimate against measurement, compound 3: 2.8-fold (0.44 log units) below, and the stated range ends below it.
By their numbers in this assay, from the lowest: compound 2; then compounds 3 and 1 (each within the scatter of the next).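

At the amide-type nitrogen, exchanging one aryl group for another is not neutral in this assay: the step is a 2.5-fold higher number from compound 2 to compound 3 (0.40 log units; beyond the scatter), even though the heavy-atom count stays the same and the two groups differ in their halogen and substitution pattern. The advantage over propyl also does not extend to every aryl group at this nitrogen, as a 1.4-fold lower number from compound 1 to compound 3 (0.15 log units; within the scatter) lies within the scatter, leaving 2-fluoro-5-(trifluoromethyl)phenyl and propyl unseparated here. No measured property of these compounds bears on the difference between the two aryl groups.

As far as these compounds go, this single exchange alters the halogens and the substitution pattern together, so their separate contributions remain open. Also open, from the compounds shown here alone, is how unsubstituted phenyl, 4-chlorophenyl or a longer alkyl chain would behave on this nitrogen.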